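The source may report more compounds than this note shows. Statements on the series, on what has been measured and on what is new or still open speak of the compounds shown alone.

Measured compounds:
compound 1, `Cc1nc(CN2CCCC2c2ccccn2)cc(N2CCN(C)CC2)n1`, "not determined" (no result reported) in the assay;
compound 2, `Cc1nc(CN2CCC[C@H]2c2ccccn2)cc(N2CCN(C)CC2)n1`, 2.7 nM;
compound 3, `Cc1nc(CN2CCC[C@@H]2c2ccccn2)cc(N2CCN(C)CC2)n1`, "not determined" (no result reported).

Three compounds share one core and differ only at a single stereocentre. Compound 1 is drawn without a defined configuration there, while compound 2 and compound 3 each carry one, and compound 2 and compound 3 differ only in the configuration as drawn (the fact that compounds 2 and 3 differ only in the configuration as drawn). Going by the values given here, in a functional assay on cells (T cell) for antagonist activity at C-X-C chemokine receptor type 4 (Homo sapiens), read by FLIPR and calcium flux, with a stated time of 20 min (on this read-out higher numbers stand for weaker inhibition and lower numbers for stronger inhibition), compound 2 gives 2.7 nM; this is the only number reported among the three, so compound 2 stands as the sole reference point, with compound 1 and compound 3 contributing no value at all.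

Compound 4, `Cc1ccc([C@@H]2CCCN2Cc2cc(N3CCN(C)CC3)nc(C)n2)nc1`, is built from compound 2 by a single change, (methyl in place of hydrogen on an aromatic carbon). Among the compounds with values here, no step between two measured compounds is available to show what such a change does on this core, so the expectation rests on the size of the change alone. A single methyl added at that place is expected to move the read-out little, so the step from compound 2 to compound 4 is estimated to stay within the scatter, a 1.1-fold higher number from compound 2 to compound 4 (0.05 log units; within the scatter). Compound 4 is therefore expected to give about 3 nM in this assay, within a range from 1 nM to 9 nM.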

Compound 4, half-maximal inhibitory concentration: 4.9 nM
Beside the measured number, compound 4's estimate is 1.6-fold (0.21 log units) below it, and the stated range covers the measured number.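

Going by these compounds alone, compound 4 gives the first reading of any change on the pyridine ring of this series: in this assay, pyridin-2-yl to 5-methylpyridin-2-yl reads as a 1.8-fold higher number from compound 2 to compound 4 (0.26 log units; within the scatter). The two compounds therefore cannot be told apart on this read-out, and a methyl on this aromatic carbon, two atoms from the ring nitrogen and para to a large group, leaves the inhibition at the low level that compound 2 alone had shown, so this position accepts one added carbon without a change that can be separated from the scatter. None of the facts available on these compounds, all of which concern the configuration at the stereocentre, bears on this methyl step, and nothing can be said about what lies behind its size.

Still open, as far as these compounds go, is whether this position would read the same with a larger or different group, such as an ethyl, a methoxy, a chlorine or a primary amine, and whether a methyl on another carbon of the ring would behave like this one. From the compounds shown here alone, the role of the configuration also stays open, as no comparison of compound 2 with compound 3 can be read.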